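Ring or Branched Chain at the Ether Oxygen

The source may hold more compounds than are shown below. What is called first, only, known or untested is meant among the compounds shown, and "the series" means these compounds.

Compound 1 `CC(C)=CCOc1cccc(O)c1C(=O)/C=C/c1ccc(O)cc1`: > 30000 nM (a limit of the assay)
Compound 2 `O=C(/C=C/c1ccc(O)cc1)c1c(O)cccc1OCCC1CCCC1`: 3200 nM
Compound 3 `O=C(/C=C/c1ccc(O)cc1)c1c(O)cccc1OCC1CCCC1`: 2140 nM

In a functional assay on NUGC-3 cells (Homo sapiens) for antiproliferative activity, read by sulforhodamine B assay (on this read-out higher numbers stand for weaker inhibition of growth and lower numbers for stronger inhibition of growth), compound 1 gives > 30000 nM, which is a limit of the assay and not a number. Compound 3 gives 2140 nM, the lowest of the two numbers; compound 2 stands nearest with 3200 nM, and a 1.5-fold lower number from compound 2 to compound 3 (0.17 log units; within the scatter) lies within the scatter. Compound 4 `CC(C)(C)CCOc1cccc(O)c1C(=O)/C=C/c1ccc(O)cc1` differs from compound 3 by neopentyl in place of cyclopentyl on a saturated chain carbon bound to an oxygen on an aromatic ring. For the measured compounds named here, no measured step exchanges a ring for a branched chain; the nearest guides are an at least 14-fold lower number from compound 1 to compound 3 (1.14 log units; beyond the scatter), where the 2-methylprop-1-en-1-yl group gave way to a ring, and a 1.5-fold lower number from compound 2 to compound 3 (0.17 log units; within the scatter). Since neopentyl keeps the same count of carbons and is free of the double bond, the step to compound 4 is expected to be a 1.4-fold higher number from compound 3 to compound 4 (0.15 log units; within the scatter). Compound 4 is therefore estimated at 3000 nM, between 1200 nM and 8000 nM.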

Compound 4, concentration for 50% growth inhibition: 3300 nM
Compound 4: the middle estimate sits 1.1-fold (0.04 log units) below what was measured; measured number inside the range.
By their numbers in this assay, from the lowest: compounds 3, 2 and 4 (each within the scatter of the next). At a limit, above all of these: compound 1.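

In this assay, an open saturated chain serves this position as well as a ring does, with a 1.5-fold higher number from compound 3 to compound 4 (0.19 log units; within the scatter) and a 1.0-fold higher number from compound 2 to compound 4 (0.01 log units; within the scatter). The gap from the 2-methylprop-1-en-1-yl group therefore does not depend on a ring, with an at least 9.0-fold lower number from compound 1 to compound 4 (0.95 log units; beyond the scatter). Compound 1 stands at a limit of the assay and not at a number: the limit of > 30000 nM in this assay, at which 1 of the 4 values shown sits.

The compounds shown leave open how an amine or a carboxylic acid at the end of this chain would read. They also leave open how 3-methylbutyl, the saturated form of the group in compound 1, would compare.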